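A Longer Amide Chain on a Flap Endonuclease Inhibitor

The source may hold more compounds than are shown below. What is called first, only, known or untested is meant among the compounds shown, and "the series" means these compounds.

The series rests on a shared core carrying a thiophene ring. Compound 1 `COc1nc(-c2cccs2)nc(C(=O)O)c1O` is part of the set, but in an assay on isolated protein for inhibition of Flap endonuclease 1 (Homo sapiens) (a lower number here means a stronger inhibitor, a higher number a weaker inhibitor), compound 1 gives "not determined" (no result reported), so no result is reported for it. Among the compounds with values here, compound 2 `CNC(=O)c1nc(-c2cccs2)[nH]c(=O)c1O` carries a methylamino group on the amide and is the only member with a number: in this assay compound 2 gives 12000 nM, which is a weak result, and with no other number it can stand neither high nor low within the set. Compound 3 `CC(C)CCNC(=O)c1nc(-c2cccs2)[nH]c(=O)c1O` is not yet measured. It differs from compound 2 in one place: isobutyl in place of hydrogen on a saturated chain carbon bound to an amide-type nitrogen. Within the data shown here, no step between two measured compounds is available to guide this change, so a large move in either direction is not expected; a growing alkyl chain on an amide commonly shifts such a read-out only modestly, and the step from compound 2 to compound 3 is expected to be a 1.5-fold lower number from compound 2 to compound 3 (0.18 log units; within the scatter), close to or slightly beyond the scatter. Compound 3 is therefore expected to give about 8000 nM in this assay, within a range from 3000 nM to 25000 nM.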

Compound 3, half-maximal inhibitory concentration: 3500 nM
Beside the measured number, compound 3's estimate is 2.3-fold (0.36 log units) above it; low and high end bracket the measured number.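

Within the data shown here, until now, the amide of the shared core had been seen only with its small methylamino group, so nothing showed whether this position responds to change. Going from methylamino to isopentylamino gives a 3.4-fold lower number from compound 2 to compound 3 (0.54 log units; beyond the scatter) in this assay, showing that this position tolerates a longer saturated chain and that the added isobutyl goes with a stronger inhibitor rather than a loss of inhibition. No measurement here explains the gain, so this single step records a change in the read-out, not its cause.

From the compounds shown here alone, it remains open whether the number would keep falling with a still longer chain, and how shorter chains such as ethyl or propyl, a cyclohexyl ring, or a chain ending in an amine or a carboxylic acid would compare. Among these compounds, with only one pair of compounds speaking to this position, it is also unknown whether the same step would hold if another group replaced the thiophene ring.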